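Removing the ethyl group from the amine of compound 3

This account rests on a few compounds, and the source may have more. Where it says the series, first, only, none or still open, it means among the compounds named here.

compound 1 `COc1ccc(C(=O)c2ccc(OC)c3c2OC(C)(C)C=C3)c(NC(=O)CO)c1`: 230 nM
compound 2 `CNCC(=O)Nc1cc(OC)ccc1C(=O)c1cc(OC)c(OC)c(OC)c1`: 780 nM
compound 3 `CCNCC(=O)Nc1cc(OC)ccc1C(=O)c1cc(OC)c(OC)c(OC)c1`: 1560 nM

All three values come from a functional assay on HCT-8 cells (Homo sapiens) for antiproliferative activity, read by MTT assay, with a stated time of 48 h; a higher number here means a weaker inhibitor, a lower number a stronger inhibitor. Compound 3 gives 1560 nM, which lies within the scatter of compound 2 and at a number beyond the scatter from that of compound 1.

The next compound is compound 4 `COc1ccc(C(=O)c2cc(OC)c(OC)c(OC)c2)c(NC(=O)CN)c1`. It differs from compound 3 as follows: hydrogen in place of ethyl on an amine nitrogen. Among the compounds with values here, only one measured step bears on this change: a 2.0-fold higher number from compound 2 to compound 3 (0.30 log units; within the scatter). Within the data shown here, that step lies within the scatter, so it offers only a weak hint of direction, and no compound with an unsubstituted amine has yet been measured. A step of similar size toward a lower number is therefore expected in this assay, and it may not clear the scatter. The expected step is a 2.0-fold lower number from compound 3 to compound 4 (0.29 log units; within the scatter). Compound 4 is estimated at 800 nM, with an expected range of 300 nM to 2000 nM.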

Compound 4, half-maximal inhibitory concentration: 330 nM
Compound 4: middle estimate off by 2.4-fold (0.38 log units), on the high side; low and high end bracket the measured number.
By their numbers in this assay, from the lowest: compounds 1 and 4 (each within the scatter of the next); then compounds 2 and 3 (each within the scatter of the next).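

In this assay hydrogen in place of ethyl on the amine nitrogen gives a 4.7-fold lower number from compound 3 to compound 4 (0.67 log units; beyond the scatter) and hydrogen in place of methyl gives a 2.4-fold lower number from compound 2 to compound 4 (0.37 log units; beyond the scatter), both beyond the scatter, while methyl to ethyl gives only a 2.0-fold higher number from compound 2 to compound 3 (0.30 log units; within the scatter) and stays within it. Within the data shown here, at this amine nitrogen, the first change that clears the scatter therefore comes with the unsubstituted amine, not between the two alkyl groups. Nothing measured here accounts for this result.

Open, on these data alone, is how a longer chain such as propyl, a second methyl on the same nitrogen as in dimethylamino, or an acetyl group on that nitrogen would read against the unsubstituted amine of compound 4. Also open, as far as these compounds go, is whether the same change holds on the core of compound 1, whose side chain carries a hydroxyl group rather than an amine.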